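The compounds below may be only part of what the source reports. "The series", "measured", "known", "first", "only" and "open" are said of these compounds alone.

In a functional assay on U-87MG ATCC cells (Homo sapiens) for inhibition (on this read-out higher numbers stand for weaker inhibition and lower numbers for stronger inhibition), compound 1 (`COc1cc(/C=C/C(=O)c2cccc(NC(=O)c3cccs3)c2)ccc1O`) gives 14.7 ug/mL. Compound 2 (`COc1cc(/C=C/C(=O)c2cccc(NC(=O)c3ccc(Cl)cc3)c2)ccc1O`) reads > 50 ug/mL, which is a limit of the assay and not a number. Compound 3 (`COc1cc(/C=C/C(=O)c2cccc(NC(=O)c3ccco3)c2)ccc1O`) follows from compound 2 by furan-2-yl in place of 4-chlorophenyl on a carbonyl carbon. Among the compounds with values here, the only measured step bearing on this is an at least 3.4-fold higher number from compound 1 to compound 2 (0.53 log units; beyond the scatter), where 4-chlorophenyl replaced thiophen-2-yl at the same place. With a five-membered aromatic ring restored, that step is expected to largely reverse, towards stronger inhibition, and the expected change is an at least 2.7-fold lower number from compound 2 to compound 3 (0.44 log units; beyond the scatter). For compound 3 the estimate is 18 ug/mL, with an expected range of 7 ug/mL to 45 ug/mL.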

Compound 3, half-maximal inhibitory concentration: 6.65 ug/mL
Estimate against measurement, compound 3: 2.7-fold (0.43 log units) above, and the stated range ends above it.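

In this assay, within the data shown here, furan-2-yl on the carbonyl carbon gives an at least 7.5-fold lower number from compound 2 to compound 3 (0.87 log units; beyond the scatter), so a five-membered aromatic ring is tolerated here in more than the one thiophen-2-yl example. The two five-membered rings also differ from each other, with a 2.2-fold lower number from compound 1 to compound 3 (0.34 log units; beyond the scatter), so the hetero atom matters at this position and not only the ring size. Compound 2 is a limit and not a number, so the first step has no fixed size: the limit of > 50 ug/mL in this assay, at which 1 of the 3 values shown sits.

Whether the chlorine or the six-membered ring accounts for the weak result of compound 2 stays open, and plain phenyl on the same carbonyl carbon would separate the two. Also open, as far as these compounds go, is whether the ring must be aromatic, which tetrahydrofuran-2-yl would address.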